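The compounds below may be only part of what the source reports. "The series", "measured", "known", "first", "only" and "open" are said of these compounds alone.

Measured so far in a functional assay on HCT-116 cells (Homo sapiens) for cytotoxicity, read by CellTiter-Glo, with a stated time of 5 days; a lower number here means a stronger inhibitor, a higher number a weaker inhibitor:
Compound 1 `COc1ccc(Cn2nc(Nc3cc(C)[nH]n3)c3ccccc3c2=O)cc1` gives 1200 nM.
Compound 2 `Cc1cc(Nc2nn(Cc3cccnc3)c(=O)c3ccccc23)n[nH]1` gives 2900 nM.
Compound 3 `Cc1cc(Nc2nn(-c3ccc(F)cc3)c(=O)c3ccccc23)n[nH]1` gives 800 nM.

Compound 1 sits second highest of the three numbers. Its nearest neighbour is compound 3, reached by a 1.5-fold lower number from compound 1 to compound 3 (0.18 log units; within the scatter), a step that stays within the scatter. Its furthest is compound 2, reached by a 2.4-fold higher number from compound 1 to compound 2 (0.38 log units; beyond the scatter), a modest step beyond the scatter. Between the other two, a 3.6-fold lower number from compound 2 to compound 3 (0.56 log units; beyond the scatter) is likewise modest and beyond the scatter.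

Compound 4 `Cc1cc(Nc2nn(Cc3ccc(S(C)(=O)=O)cc3)c(=O)c3ccccc23)n[nH]1` is next, differing from compound 1 by methylsulfonyl in place of methoxy on an aromatic carbon. Within the data shown here, no measured step alters only the group on this ring: the two steps from compound 1 exchange the whole group on the aromatic nitrogen, and both are small to modest. The substituent exchange on an otherwise retained benzyl group is therefore expected to move this assay little, with no step beyond the scatter and, if anything, a slightly higher number.

Compound 4 is thus estimated at 1500 nM, with a range of 600 nM to 4000 nM, which means an expected step of a 1.3-fold higher number from compound 1 to compound 4 (0.10 log units; within the scatter).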

Compound 4, half-maximal inhibitory concentration: 1700 nM
Estimate against measurement, compound 4: 1.1-fold (0.05 log units) below, within the range that was stated.
By their numbers in this assay, from the lowest: compounds 3, 1, 4 and 2 (each within the scatter of the next, the first and the last beyond it).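

Working notes on the group para to a large group on the benzyl ring: compound 4 gives the first reading of a change confined to this aromatic carbon, as the earlier steps exchanged the whole group on the aromatic nitrogen. In this assay, replacing methoxy with methylsulfonyl gives a 1.4-fold higher number from compound 1 to compound 4 (0.15 log units; within the scatter), so this exchange cannot be told apart from repeat measurement. The entering group has 4 heavy atoms against 2 for methoxy and 2 hydrogen-bond acceptors against 1, yet this assay registers no clear shift across this pair. Nothing available bears on why this exchange leaves the reading so close.

Open, as far as these compounds go, is whether an amine or a carboxylic acid on this same carbon would also stay within the scatter of compound 1. Also open, from the compounds shown here alone, is whether a longer chain on the aromatic nitrogen, carrying this same ring, would keep this flat response.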